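A few compounds are considered here, and "the series" means these few. Any claim that something is new, unique, unknown or untested is made for them only; others in the source may bear on it.

Measured compounds in a functional assay on HT-29 cells (Homo sapiens) for antiproliferative activity, with a stated time of 48 h; a higher number here means a weaker inhibitor, a lower number a stronger inhibitor:
- compound 1 `CC(C)(C)c1ccc(NC(=O)NCCCCl)cc1` gives 28000 nM
- compound 2 `CC(C)(C)c1ccc(NC(=O)CCl)cc1` gives 15000 nM
- compound 3 `O=C(CCCCl)Nc1ccc(I)cc1` gives > 100000 nM, which is a limit of this assay rather than a number

Compound 3 therefore stands at the top edge of what this assay reports (the limit of > 100000 nM in this assay, at which 1 of the 3 values shown sits). Compound 4 `CC(C)(C)c1ccc(NC(=O)CCCCl)cc1` differs from it by tert-butyl in place of iodo on an aromatic carbon. Among the measured compounds shown here, no measured step changes that aromatic substituent; the only measured step, a 1.9-fold lower number from compound 1 to compound 2 (0.27 log units; within the scatter), alters the group on the carbonyl carbon and lies within the scatter. Compound 4 shares its tert-butyl group with compound 1 and compound 2, whose values are numbers rather than limits. Given that compound 2 gives 15000 nM and compound 1 gives 28000 nM, compound 4 is expected near 30000 nM, between 8000 nM and 120000 nM. That estimated move is an at least 3.3-fold lower number from compound 3 to compound 4 (0.52 log units; beyond the scatter).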

Compound 4, half-maximal inhibitory concentration: > 100000 nM
Compound 4 was reported as a limit; the forecaster's own chance of this, stated with the estimate: 30%; at least 3.3-fold (0.52 log units) between middle value and limit.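

The swap of iodo for tert-butyl on the aromatic carbon cannot be read, because compound 3 and compound 4 both stand at a limit of the assay rather than at a number: the limit of > 100000 nM in this assay, at which 2 of the 4 values shown sit.

With tert-butyl kept, the group on the carbonyl carbon now shows steps beyond the scatter in this assay: 2-chloroethyl in place of chloro gives an at least 6.6-fold higher number from compound 2 to compound 4 (0.82 log units; beyond the scatter), and 3-chloropropyl in place of (3-chloropropyl)amino gives an at least 3.5-fold higher number from compound 1 to compound 4 (0.55 log units; beyond the scatter).

Going by these compounds, whether an amine in place of tert-butyl on the aromatic carbon would give a number stays open, as does the effect of a longer chain on the carbonyl carbon.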